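Urea aryl variation on the indole-thioether pyrimidine series

A few compounds are considered here, and "the series" means these few. Any claim that something is new, unique, unknown or untested is made for them only; others in the source may bear on it.

The shared core carries an indolyl thioether, a substituted piperazine and an aryl urea, and is followed in a functional assay on HepG2 cells (Homo sapiens) for inhibition, with a stated time of 72 h; on this read-out lower numbers stand for stronger inhibition and higher numbers for weaker inhibition. Compound 1 `O=C(Nc1ccccc1)Nc1nc(Sc2c[nH]c3ccccc23)cc(N2CCN(Cc3ccccc3)CC2)n1` gives 8160 nM and stands second highest of the three numbers measured; its nearest neighbour is compound 3, its furthest compound 2, and both gaps lie within the scatter. Compound 2 `O=C(Nc1ccccc1)Nc1nc(Sc2c[nH]c3ccccc23)cc(N2CCN(c3ccccn3)CC2)n1` gives 8930 nM in this assay, and compound 3 `Cc1cc(Cl)ccc1NC(=O)Nc1nc(Sc2c[nH]c3ccccc23)cc(N2CCN(c3ccccn3)CC2)n1` gives 7640 nM. The two steps measured so far are flat: a 1.1-fold higher number from compound 1 to compound 2 (0.04 log units; within the scatter) and a 1.2-fold lower number from compound 2 to compound 3 (0.07 log units; within the scatter), neither beyond the scatter.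

Compound 4 `Cc1ccc(C)c(NC(=O)Nc2nc(Sc3c[nH]c4ccccc34)cc(N3CCN(Cc4ccccc4)CC3)n2)c1` is the next member and has not yet been measured. It differs from compound 1 in one place: 2,5-dimethylphenyl in place of phenyl on an amide-type nitrogen. Among the measured compounds shown here, the step that bears on this is the one from compound 2 to compound 3, where another substituted aryl replaced phenyl on the same amide-type nitrogen and gave a 1.2-fold lower number from compound 2 to compound 3 (0.07 log units; within the scatter), a change within the scatter. On that basis no step beyond the scatter is expected in this assay, in either direction, and compound 4 is expected to sit near its parent, a 1.0-fold lower number from compound 1 to compound 4 (0.02 log units; within the scatter). The estimate for compound 4 in this assay is 7800 nM, with a range from 3500 nM to 17000 nM.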

Compound 4, half-maximal inhibitory concentration: 16400 nM
The estimate for compound 4 lay 2.1-fold (0.32 log units) below the measured number; measured number inside the range.
By their numbers in this assay, from the lowest: compounds 3, 1, 2 and 4 (each within the scatter of the next, the first and the last beyond it).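

Among the compounds shown here, on the benzyl-bearing parent, 2,5-dimethylphenyl in place of phenyl on the amide-type nitrogen gives, in this assay, a 2.0-fold higher number from compound 1 to compound 4 (0.30 log units; within the scatter), the largest step seen so far but still not beyond the scatter. Read together with a 1.2-fold lower number from compound 2 to compound 3 (0.07 log units; within the scatter), on the pyridin-2-yl parent, this extends the observation to both piperazine substituents: in these two pairs, a substituted aryl in place of phenyl at this position gives no step beyond the scatter, and the flat picture no longer rests on a single parent. No measurement at hand bears on what lies behind the size of this step.

Still open, as far as these compounds go, is whether 2,5-dimethylphenyl behaves the same way on the pyridin-2-yl parent, and whether a single methyl, as in 2-methylphenyl, would give a similar step on either parent. Also open, from the compounds shown here alone, is whether groups of a different kind at this position, such as an aryl carrying a carboxylic acid or an amine, or a longer chain on the amide-type nitrogen, would move the number beyond the scatter.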